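Compound 2 to compound 4: changing the group on the amine nitrogen

The source may report more compounds than this note shows. Statements on the series, on what has been measured and on what is new or still open speak of the compounds shown alone.

In a functional assay on ECa-109 cells for inhibition, with ECa-109 cell line (Homo sapiens) as the target, read by sulforhodamine B assay (on this read-out lower numbers stand for stronger inhibition and higher numbers for weaker inhibition), three compounds have been read so far. Compound 1 `O=C1C(Nc2ccc(I)cc2)=CC(=O)c2c1nc1n2[C@H]2OC[C@@H](O)[C@H]2OC1` gives 2530 nM. Compound 3 `O=C1C(Nc2ccccc2F)=CC(=O)c2c1nc1n2[C@H]2OC[C@@H](O)[C@H]2OC1` gives 2660 nM. Compound 2 `CCCc1ccc(NC2=CC(=O)c3nc4n(c3C2=O)[C@H]2OC[C@@H](O)[C@H]2OC4)cc1` gives > 4000 nM, which is a limit of the assay and not a number.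

The next step leads to compound 4 `O=C1C=C(Nc2ccccc2F)C(=O)c2c1nc1n2[C@H]2OC[C@@H](O)[C@H]2OC1`: 2-fluorophenyl in place of 4-propylphenyl on an amine nitrogen. The 2-fluorophenyl group thus replaces 4-propylphenyl on an amine nitrogen.

Among the measured compounds shown here, one measured step bears on this change: a 1.1-fold higher number from compound 1 to compound 3 (0.02 log units; within the scatter). It also brings in 2-fluorophenyl on an amine nitrogen, but it starts from 4-iodophenyl and stays within the scatter. Compound 3 is the closest guide because it carries the same group at 2660 nM. Its structure still differs from that of compound 4, and no measurement covers that difference.

A number in the same region as compound 3 is therefore expected, which would lie on the lower side of the limit. The expected step is an at least 1.6-fold lower number from compound 2 to compound 4 (0.20 log units; that floor lies within the scatter), toward a lower number, with its true size left loose by the limit at the start. Compound 4 is estimated at 2500 nM, with an expected range of 1000 nM to 5000 nM.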

Compound 4, half-maximal inhibitory concentration: 2760 nM
Beside the measured number, compound 4's estimate is 1.1-fold (0.04 log units) below it, within the range that was stated.
By their numbers in this assay, from the lowest: compounds 1, 3 and 4 (each within the scatter of the next). At a limit, above all of these: compound 2.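

In this assay, 2-fluorophenyl in place of 4-propylphenyl on an amine nitrogen gives an at least 1.4-fold lower number from compound 2 to compound 4 (0.16 log units; that floor lies within the scatter), so this change moves the read-out from a limit to a measured number, although the floor of the step does not go beyond the scatter. From the compounds shown here alone, the true size of the step stays open because compound 2 sits at a limit of the assay, not at a number: the limit of > 4000 nM in this assay, at which 1 of the 4 values shown sits. Compound 4 carries the same 2-fluorophenyl group on an amine nitrogen as compound 3, and the printed values, compound 3 at 2660 nM and compound 4 at 2760 nM, lie within the scatter of each other, so the two placements of this group on the core cannot be told apart in this read-out.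

It remains open whether the propyl chain itself sets compound 2 apart, since the series shown offers no reading for a shorter chain such as ethyl or for a plain phenyl group on this nitrogen. Going by these compounds, how a carboxylic acid or an amine on the phenyl ring would read also remains open.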